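The source may report more compounds than this note shows. Statements on the series, on what has been measured and on what is new or still open speak of the compounds shown alone.

Compound 2 `COc1cc(-c2nn(-c3ccccc3)cc2C(=O)/C=C\Nc2ccc(Cl)cc2)cc(OC)c1OC` gives 8670 nM in a functional assay on A549 cells (Homo sapiens) for antiproliferative activity, read by MTT assay, with a stated time of 48 h; on this read-out higher numbers stand for weaker inhibition and lower numbers for stronger inhibition. Compound 1 `COc1cc(-c2nn(-c3ccccc3)cc2C(=O)/C=C\Nc2ccc(F)cc2)cc(OC)c1OC` gives 15600 nM in this assay, and the step of a 1.8-fold lower number from compound 1 to compound 2 (0.26 log units; within the scatter) shows the two sit within the scatter of each other, so neither can be called the stronger. Compound 3 `COc1cc(-c2nn(-c3ccccc3)cc2C(=O)/C=C\Nc2ccc(C(F)(F)F)cc2)cc(OC)c1OC` differs from compound 2 by trifluoromethyl in place of chloro on an aromatic carbon. Among the measured compounds shown here, only one measured step bears on this place, and it stayed within the scatter, so nothing here points to a large shift; the step expected is a 1.2-fold lower number from compound 2 to compound 3 (0.09 log units; within the scatter). Compound 3 is estimated at 7000 nM, with a range from 2500 nM to 20000 nM.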

Compound 3, half-maximal inhibitory concentration: > 50000 nM
Compound 3 was reported as a limit (the forecaster's own chance of this, stated with the estimate: 5%); middle value at least 7.1-fold (0.85 log units) away from the limit.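

This position does tolerate some change, but not every change: fluoro and chloro stayed within the scatter of each other, whereas trifluoromethyl gives an at least 5.7-fold higher number from compound 2 to compound 3 (0.76 log units; beyond the scatter) and an at least 3.2-fold higher number from compound 1 to compound 3 (0.50 log units; beyond the scatter) in this assay. Among the compounds shown here, on this read-out, a higher number means weaker inhibition, so this is the first clear loss seen at this place. Compound 3 has no exact value, only a limit: the limit of > 50000 nM in this assay, at which 1 of the 3 values shown sits.

The compounds shown leave open how an amine, a nitrile or a carboxylic acid would read at this place. They also leave open how far inhibition falls with trifluoromethyl.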